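From neopentyl to 1-phenylethyl at the nitrogen

This account rests on a few compounds, and the source may have more. Where it says the series, first, only, none or still open, it means among the compounds named here.

Compound 1 `C[C@@H](/N=c1\c(O)c(O)\c1=N/c1cccnc1)C(C)(C)C` gives 1900 nM (a measured number)
Compound 2 `CC(C)(C)C/N=c1\c(O)c(O)\c1=N/c1ccc(C#N)cc1` gives > 30000 nM (a limit of the assay)

The result for compound 2 in a functional assay for inhibition, with Rattus norvegicus as the target (a lower number here means a stronger inhibitor, a higher number a weaker inhibitor), is a limit, > 30000 nM, and not a number. Compound 3 `C[C@H](/N=c1\c(O)c(O)\c1=N/c1ccc(C#N)cc1)c1ccccc1` carries 1-phenylethyl in place of neopentyl on a double-bonded nitrogen. Within the data shown here, no measured step covers this change, so its size is uncertain. Among the measured compounds shown here, the expected at least 6.0-fold lower number from compound 2 to compound 3 (0.77 log units; beyond the scatter) points toward stronger inhibition, though only modestly, since the sole number so far is that of compound 1 (1900 nM). For compound 3 the estimated value is 5000 nM, with an expected range from 800 nM to 30000 nM.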

Compound 3, half-maximal inhibitory concentration: > 30000 nM
Compound 3 ended at the assay's limit; the forecaster's own chance of this, stated with the estimate: 35%; middle value at least 6.0-fold (0.77 log units) away from the limit.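

Compound 2 and compound 3 both end at a limit of the assay and not at a number, so no step between them can be read: the limit of > 30000 nM in this assay, at which 2 of the 3 values shown sit.

From the compounds shown here alone, whether 1-phenylethyl in place of neopentyl changes inhibition at all stays open.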